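This account rests on a few compounds, and the source may have more. Where it says the series, first, only, none or still open, it means among the compounds named here.

Working notes on the series. Of the compounds shown here, three have been measured so far in a functional assay on HCT-116 cells (Homo sapiens) for antiproliferative activity, read by CCK-8 assay, with a stated time of 72 h, tested at 2 uM; on this read-out higher numbers stand for a stronger effect at the one concentration tested and lower numbers for a weaker effect. Compound 1 `CC(C)n1cnc2c(Nc3cccc(Cl)c3)nc(NCOCc3ccc(C(=O)Nc4ccccc4N)cc3)nc21` gives 7.12%. Compound 2 `CCCCn1cnc2c(Nc3ccccc3)nc(NCOCc3ccc(/C=C/C(=O)Nc4ccccc4N)cc3)nc21` gives 6.58%. Compound 3 `Nc1ccccc1NC(=O)c1ccc(Cn2cnc3c(Nc4ccccc4)nc(Cl)nc32)cc1` gives 71.4%. On these numbers compound 2 stands lowest of the three; the figure of compound 1 lies within the scatter of it, so those two cannot be told apart, whereas the figure of compound 3 lies beyond the scatter and is clearly higher. Among the compounds with values here, no two of the measured compounds differ in only one place, so no single-change step among measured compounds is on hand; compound 1 and compound 2 differ in more than one place and still give figures within the scatter of each other.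

Compound 4 `Nc1ccccc1NC(=O)/C=C/c1ccc(COCNc2nc(Nc3ccccc3)c3ncn(C4CCCC4)c3n2)cc1` has not yet been measured. Against compound 2 it differs in one place: cyclopentyl in place of butyl on an aromatic nitrogen. Within the data shown here, nothing among the measured compounds shows what such an exchange does, so the expectation rests on the weak read-out of compound 2 alone. The step from compound 2 to compound 4 in this assay is expected to be small and not beyond the scatter, in either direction; the estimate means a step of a number 2.4 percentage points higher from compound 2 to compound 4 (within the scatter). Compound 4 is therefore estimated at 9%, with a range from 0% to 25%.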

Compound 4, a percentage reported as inhibition, at one concentration (the size of the read-out at that concentration, not a potency): 10.5%
Beside the measured number, compound 4's estimate is 1.5 percentage points below it; the measured number falls inside the stated range.
By their numbers in this assay, from the lowest: compounds 2, 1 and 4 (each within the scatter of the next); then compound 3.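

In this assay, within the data shown here, the exchange of butyl for cyclopentyl on an aromatic nitrogen of the five-membered aromatic ring provides the first single-change comparison, amounting to a number 3.9 percentage points higher from compound 2 to compound 4 (within the scatter). For this one pair, the open butyl chain and the five-membered non-aromatic ring of carbon only cannot be told apart, so adding a ring at this position does not separate the two compounds, and both stay at a low level of effect at the one concentration tested. No measurement on hand offers an explanation for this result.

Still open, going by these compounds, is whether a different group on this aromatic nitrogen, such as methyl, a longer chain such as octyl, or a chain ending in an amine or a carboxylic acid, would give a step beyond the scatter from compound 2. Also open, on these data alone, is whether the exchange of butyl for cyclopentyl would give a similarly small step on a compound with a stronger read-out, as the present comparison rests on a single pair with low figures.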